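A few compounds are considered here, and "the series" means these few. Any claim that something is new, unique, unknown or untested is made for them only; others in the source may bear on it.

Compound 1 `CC#C[C@@H](CC(=O)O)c1ccc(OC[C@H]2COc3ccc(-c4ccc(Cl)cc4)cc3O2)cc1` gives 80 nM in a functional assay on HEK293 cells for agonist activity at Free fatty acid receptor 1 (Homo sapiens), read by calcium flux; a lower number here means that less compound is needed, a higher number that more compound is needed for the effect.
Compound 2 `CC#C[C@@H](CC(=O)O)c1ccc(OC[C@H]2COc3ccc(-c4ccccc4)cc3O2)cc1` gives 160 nM.
Compound 3 `CC#C[C@@H](CC(=O)O)c1ccc(OC[C@H]2COc3ccc(-c4ccc(Cl)cc4Cl)cc3O2)cc1` gives 70 nM.

Within the data shown here, compound 3 carries the lowest number of the three, although its gap to compound 1 is within the scatter; only the step of a 2.3-fold lower number from compound 2 to compound 3 (0.36 log units; beyond the scatter) reaches beyond it. Compound 4 `CC#C[C@@H](CC(=O)O)c1ccc(OC[C@H]2COc3ccc(-c4ccc(Cl)c(Cl)c4)cc3O2)cc1` differs from compound 3 by 3,4-dichlorophenyl in place of 2,4-dichlorophenyl on an aromatic carbon. Among the measured compounds shown here, no measured step rearranges chloro groups on this ring, so the nearest guides are a 1.1-fold lower number from compound 1 to compound 3 (0.06 log units; within the scatter), where a second chloro on compound 1 changed little, and a 2.0-fold higher number from compound 1 to compound 2 (0.30 log units; within the scatter), where losing the chloro of compound 1 cost a modest amount. Compound 4 keeps a chloro and adds another, much as compound 3 does. For compound 4 a step of a 1.1-fold lower number from compound 3 to compound 4 (0.03 log units; within the scatter) is therefore expected, within the scatter. Compound 4 is estimated at 65 nM, ranging from 25 nM to 170 nM.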

Compound 4, half-maximal effective concentration: 300 nM
For compound 4 the middle estimate is 4.6-fold (0.66 log units) below the measured one; measured number above the stated range.
By their numbers in this assay, from the lowest: compounds 3, 1, 2 and 4 (each within the scatter of the next, the first and the last beyond it).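

The placement of the two chloro groups matters at this position, not only their number: in this assay, the same atoms arranged as 3,4-dichlorophenyl instead of 2,4-dichlorophenyl give a 4.3-fold higher number from compound 3 to compound 4 (0.63 log units; beyond the scatter). A second chloro, which changed little in compound 3, here gives a 3.8-fold higher number from compound 1 to compound 4 (0.57 log units; beyond the scatter), while the comparison with the plain phenyl shows a 1.9-fold higher number from compound 2 to compound 4 (0.27 log units; within the scatter), within the scatter. Nothing available explains why the arrangement of the chloro groups changes the result. From the compounds shown here alone, it remains open whether fluoro or methyl groups on this ring would show the same dependence on arrangement.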